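Replacing a Sulfonamide Side Group with a Cyclohexyl Urea

The compounds below may be only part of what the source reports. "The series", "measured", "known", "first", "only" and "open" are said of these compounds alone.

Three compounds share one core and differ only in the group attached to a saturated chain carbon bound to an aromatic carbon. Compound 1 `CCCCc1ccc(CNC(=O)OC(C)(C)C)c(=O)n1Cc1ccc(-c2ccccc2-c2nn[nH]n2)cc1` gives 68.9% in a functional assay on the whole organism (artery) for inhibition, with Rattus norvegicus as the target, at a dose of 3 mg/kg by the intraduodenal route; a higher number here means more inhibition at the dose given (going by the name of the read-out), a lower number less inhibition. Compound 2 `CCCCc1ccc(CN(C)S(=O)(=O)c2ccccc2)c(=O)n1Cc1ccc(-c2ccccc2-c2nn[nH]n2)cc1` gives 68.7% in this assay. Compound 3 `CCCCc1ccc(CN(Cc2ccccc2)S(C)(=O)=O)c(=O)n1Cc1ccc(-c2ccccc2-c2nn[nH]n2)cc1` gives 41.2%, the lowest of the three: the steps of a number 27.7 percentage points lower from compound 1 to compound 3 (beyond the scatter) and a number 27.5 percentage points lower from compound 2 to compound 3 (beyond the scatter) both lie beyond the scatter, whereas a number 0.2 percentage points lower from compound 1 to compound 2 (within the scatter) does not.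

Compound 4 `CCCCc1ccc(CNC(=O)NC2CCCCC2)c(=O)n1Cc1ccc(-c2ccccc2-c2nn[nH]n2)cc1` has not been measured yet. Its change from compound 3 is (cyclohexylcarbamoyl)amino in place of benzyl(methylsulfonyl)amino on a saturated chain carbon bound to an aromatic carbon. The two steps that bear on this change are the ones leading into compound 3, a number 27.7 percentage points lower from compound 1 to compound 3 (beyond the scatter) and a number 27.5 percentage points lower from compound 2 to compound 3 (beyond the scatter), each a modest drop. The entering group, like the (tert-butoxycarbonyl)amino group of compound 1, carries hydrogen-bond donors and a carbonyl, so the step is expected to run back upward by a comparable amount. Compound 4 is therefore expected to give about 60% in this assay, between 35% and 80%, which means an expected step of a number 18.8 percentage points higher from compound 3 to compound 4 (beyond the scatter).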

Compound 4, a percentage reported as inhibition, in the whole organism at one dose (the size of the read-out at that dose, not a potency): 0%
Beside the measured number, compound 4's estimate is 60 percentage points above it, outside the stated range (below it).
By their numbers in this assay, from the lowest: compound 4; then compound 3; then compounds 2 and 1 (each within the scatter of the next).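

Within the data shown here, at this position the side group can remove the whole effect: in this assay compound 4 gives 0%, with a number 41.2 percentage points lower from compound 3 to compound 4 (beyond the scatter) and a number 68.7 percentage points lower from compound 2 to compound 4 (beyond the scatter), whereas the earlier compounds showed only a modest loss. The closest comparison is a number 68.9 percentage points lower from compound 1 to compound 4 (beyond the scatter), where cyclohexylamino replaces tert-butoxy on a carbonyl carbon, so a carbonyl on this side chain does not by itself preserve the read-out. Nothing measured here accounts for this collapse.

The compounds shown leave open whether the loss follows the cyclohexyl ring or the urea link, which a urea bearing a tert-butyl group or a cyclohexyl carbamate would help to separate. A single dose also leaves open whether compound 4 would show any effect at a higher dose.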